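Inverting one stereocentre in a compound at the assay limit

The source may report more compounds than this note shows. Statements on the series, on what has been measured and on what is new or still open speak of the compounds shown alone.

Measured in a functional assay on L1210 cells (Mus musculus), read by MTT assay; on this read-out lower numbers stand for stronger inhibition and higher numbers for weaker inhibition:
- compound 1 (`Nc1ccn([C@@H]2O[C@H](CO)[C@](O)(C3CC3)[C@H]2O)c(=O)n1`): > 350000 nM (a limit)
- compound 2 (`C#C[C@@]1(O)[C@H](O)[C@@H](CO)O[C@H]1n1ccc(N)nc1=O`): > 350000 nM (a limit)

Within the data shown here, neither measured compound gives a number, so the series has no measured step to draw on. Compound 2 stands at > 350000 nM in this assay, and this is a limit of the assay. Its position is shared, as the limit of > 350000 nM in this assay, at which 2 of the 2 values shown sit, shows.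

The next compound is compound 3 (`C#C[C@]1(O)[C@H](O)[C@@H](CO)O[C@H]1n1ccc(N)nc1=O`). Its difference from compound 2 is purely one of configuration: the two compounds have the same atoms and bonds and differ only in configuration as drawn: 1 of 4 stereo elements differ; a stereocentre at a saturated ring carbon is drawn R in compound 2 and S in compound 3.

Among the measured compounds shown here, no measured pair shows what such an inversion does here. The expected size of an at least 1.1-fold lower number from compound 2 to compound 3 (0.06 log units; that floor lies within the scatter) is therefore none beyond the scatter, with any shift more likely towards stronger inhibition, since compound 2 sits at > 350000 nM. Compound 3 is expected at 300000 nM, with an estimated range from 30000 nM to 400000 nM.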

Compound 3, half-maximal inhibitory concentration: > 350000 nM
Compound 3 was reported as a limit; the forecaster's own chance of this, stated with the estimate: 65%; middle value at least 1.1-fold (0.06 log units) from the limit.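

Compound 2 and compound 3 both stand at the limit of this assay, so no step between them can be read: the limit of > 350000 nM in this assay, at which 3 of the 3 values shown sit.

The compounds shown leave open whether drawing this saturated ring carbon as R or as S changes inhibition in this assay at all.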